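The source may hold more compounds than are shown below. What is called first, only, known or untested is meant among the compounds shown, and "the series" means these compounds.

In a functional assay on SK-MEL-5 cells (Homo sapiens) for cytotoxicity, read by sulforhodamine B assay, with a stated time of 48 h, tested at 0.01 uM (a lower number here means a stronger effect, a higher number a weaker effect of the compound at the concentration tested), three compounds of one shared core have been measured. Compound 1 `COc1cc(-c2cc(/C=C/C(=O)c3ccc(N)cc3)[nH]n2)cc(OC)c1OC` gives 95%. Compound 2 `COc1ccc(C(=O)/C=C/c2cc(-c3cc(OC)c(OC)c(OC)c3)n[nH]2)cc1OC` gives 97%, and compound 3 `COc1ccc(C(=O)/C=C/c2cc(-c3cc(OC)c(OC)c(OC)c3)n[nH]2)cc1` gives 100%. Compound 2 thus stands second highest of the three numbers, with the step of a number 2 percentage points higher from compound 1 to compound 2 (within the scatter) and the step of a number 3 percentage points higher from compound 2 to compound 3 (within the scatter) both within the scatter.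

Compound 4 `COc1cc(C(=O)/C=C/c2cc(-c3cc(OC)c(OC)c(OC)c3)n[nH]2)cc(OC)c1OC` differs from compound 2 by methoxy in place of hydrogen on an aromatic carbon. The step of a number 3 percentage points higher from compound 2 to compound 3 (within the scatter) concerns the same kind of change on the same ring in the opposite direction, and the step of a number 2 percentage points higher from compound 1 to compound 2 (within the scatter) also alters that ring; neither exceeds the scatter. No step beyond the scatter is therefore expected. Compound 4 is estimated at 96%, between 85% and 100%, an expected step of a number 1 percentage points lower from compound 2 to compound 4 (within the scatter).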

Compound 4, a percentage reported as activity, at one concentration (the size of the read-out at that concentration, not a potency): 96%
Beside the measured number, compound 4's estimate shows no gap at the digits printed; low and high end bracket the measured number.
By their numbers in this assay, from the lowest: compounds 1, 4, 2 and 3 (each within the scatter of the next).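

In this assay, methoxy in place of hydrogen, ortho to a methoxy group and meta to a large group, gives a number 1 percentage points lower from compound 2 to compound 4 (within the scatter). With a number 3 percentage points higher from compound 2 to compound 3 (within the scatter), this shows that adding or removing a methoxy on this ring leaves the number within the scatter in both directions, so this position has not yet shown any sensitivity to the change. Nothing available explains this result. On these data alone, whether a hydroxy group, a chlorine atom or a longer chain such as ethoxy at this position would give a step beyond the scatter remains open.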